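Fluoro in place of methoxy: working notes on the series

A few compounds are considered here, and "the series" means these few. Any claim that something is new, unique, unknown or untested is made for them only; others in the source may bear on it.

In an ADME assay on L02 cells (Homo sapiens) for cytotoxicity, read by MTT assay, with a stated time of 24 h (a lower number here means a stronger inhibitor of growth, a higher number a weaker inhibitor of growth), compound 1 `CC(C)=CCN1C(=O)/C(=N/NC(=O)c2ccc(F)cc2)c2ccccc21` gives > 200000 nM, and this is a limit of the assay, not a number.

In this assay, among the measured compounds shown here, compound 2 `COc1ccc(C(=O)N/N=C2/C(=O)N(CC=C(C)C)c3ccccc32)cc1OC` gives 178000 nM, the only actual number so far. For the measured compounds named here, the values for these two compounds therefore offer no measured step to work from.

Compound 3 `COc1ccc(C(=O)N/N=C2/C(=O)N(CC=C(C)C)c3ccccc32)cc1F` follows from compound 2 by one change, fluoro in place of methoxy on an aromatic carbon. The change sits ortho to a methoxy group and meta to a large group.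

Going by the values given here, no measured step covers this change, so the expectation rests on compound 2 at 178000 nM. In this assay no step beyond the usual scatter is expected, and no direction is favoured. The expected change is a 1.0-fold lower number from compound 2 to compound 3 (0.02 log units; within the scatter), and a reading that reaches the limit of the assay would not be a surprise.

For compound 3 the estimated value is 170000 nM, with an expected range from 90000 nM to 280000 nM.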

Compound 3, concentration for 50% growth inhibition: > 200000 nM
Compound 3 ended at the assay's limit (the forecaster's own chance of this, stated with the estimate: 35%); middle value at least 1.1-fold (0.07 log units) away from the limit.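

With fluoro in place of methoxy on this aromatic carbon, ortho to a methoxy group and meta to a large group, the series gains its first step with a readable floor: an at least 1.1-fold higher number from compound 2 to compound 3 (0.05 log units; that floor lies within the scatter). On these data alone, compound 3 gives > 200000 nM in this assay, and this is a limit of the assay, not a number, so the step fixes only a minimum and its true size stays unknown. The step between compound 1 and compound 3 cannot be read, as both values are limits, and this ceiling restricts what the series can show at this position: the limit of > 200000 nM in this assay, at which 2 of the 3 values shown sit.

As far as these compounds go, how far the true value of compound 3 lies from that of compound 2, and so whether this change has any real effect in this assay, remains open. Also open, from the compounds shown here alone, is whether an amine or a carboxylic acid on this aromatic carbon, in place of the fluoro, would give a reading inside the range of this assay.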